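A few compounds are considered here, and "the series" means these few. Any claim that something is new, unique, unknown or untested is made for them only; others in the source may bear on it.

Measured in an assay on isolated protein for inhibition of DNA topoisomerase 1 (Homo sapiens), with a stated time of 30 min, tested at 100 uM; on this read-out lower numbers stand for a weaker effect and higher numbers for a stronger effect at the one concentration tested:

Compound 1, `Oc1cccc(-c2cc(-c3cccc(Cl)c3)nc(-c3ccccn3)c2)c1`, gives 0.4%.
Compound 2, `Oc1cccc(-c2cc(-c3cccc(Cl)c3)nc(-c3ccco3)c2)c1`, gives 5.5%.
Compound 3, `Oc1cccc(-c2cc(-c3cccc(Cl)c3)nc(-c3cccs3)c2)c1`, gives 7.6%.

All three compounds share one core and differ only in the group attached next to the ring nitrogen. Compound 3 has the highest of the three numbers, but this says little: the steps of a number 2.1 percentage points higher from compound 2 to compound 3 (within the scatter) and a number 7.2 percentage points higher from compound 1 to compound 3 (within the scatter) are both within the usual scatter of this kind of measurement, so the three compounds cannot be told apart on these numbers.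

Compound 4, `Oc1cccc(-c2cc(-c3ccccc3)nc(-c3cccc(Cl)c3)c2)c1`, has not yet been measured. It differs from compound 3 in one place: phenyl in place of thiophen-2-yl on an aromatic carbon. Going by the values given here, every measured step so far concerns an exchange of the group at this same position, and none of them moved the read-out beyond the scatter: a number 5.1 percentage points higher from compound 1 to compound 2 (within the scatter), a number 7.2 percentage points higher from compound 1 to compound 3 (within the scatter) and a number 2.1 percentage points higher from compound 2 to compound 3 (within the scatter). On that basis the exchange for phenyl is expected to behave the same way, with no step beyond the scatter in this assay. The expected step is a number 2.6 percentage points lower from compound 3 to compound 4 (within the scatter). Compound 4 is therefore estimated at 5%, within a range from 0% to 15%.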

Compound 4, a percentage reported as inhibition, at one concentration (the size of the read-out at that concentration, not a potency): 11.5%
Beside the measured number, compound 4's estimate is 6.5 percentage points below it; the range from low to high includes it.
By their numbers in this assay, from the lowest: compounds 1, 2, 3 and 4 (each within the scatter of the next, the first and the last beyond it).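

In this assay, going by these compounds alone, the group next to the ring nitrogen can now be seen to affect the read-out, as the exchange of pyridin-2-yl for phenyl gives the only step at this position beyond the scatter, a number 11.1 percentage points higher from compound 1 to compound 4 (beyond the scatter) and thus still a modest one. Phenyl cannot be separated from either five-membered aromatic ring, with a number 3.9 percentage points higher from compound 3 to compound 4 (within the scatter) and a number 6 percentage points higher from compound 2 to compound 4 (within the scatter), so among these groups only the pair of phenyl and pyridin-2-yl can be told apart. Nothing available explains why this pair differs while the other exchanges do not.

On these data alone, all four groups at this position are single aromatic rings, so it remains open how an amine, a carboxylic acid or a longer alkyl chain would read there in this assay. As far as these compounds go, it is also open whether a substituted phenyl, such as a 3-hydroxyphenyl or a 3-chlorophenyl group at this position, would differ from plain phenyl, and whether the modest step would carry over to a true potency measurement rather than a read-out at one concentration.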